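The source may report more compounds than this note shows. Statements on the series, on what has been measured and on what is new or still open speak of the compounds shown alone.

Measured in a functional assay on cells (Platelet, Homo sapiens) for inhibition; on this read-out higher numbers stand for weaker inhibition and lower numbers for stronger inhibition:
Compound 1 `CCOC(=O)c1ccc(-c2nn(Cc3ccccc3Cl)c3ccccc23)cc1` gives > 10000 nM, a limit of the assay.
Compound 2 `CCOC(=O)c1ccc(-c2nn(Cc3cccc(Cl)c3)c3ccccc23)cc1` gives > 10000 nM, a limit of the assay.
Compound 3 `CCOC(=O)c1ccc(-c2nn(Cc3ccc(OC)cc3)c3ccccc23)cc1` gives > 10000 nM, a limit of the assay.

Compound 1 stands only at a limit; no number places it among the others, and the two further values shown are limits as well (the limit of > 10000 nM in this assay, at which 3 of the 3 values shown sit). Compound 4 `CCOC(=O)c1ccc(-c2nn(-c3ccco3)c3ccccc23)cc1` differs from compound 1 in furan-2-yl in place of 2-chlorobenzyl on an aromatic nitrogen. The measured steps that touch the same position, a step that the two limits leave unreadable from compound 1 to compound 2 and a step that the two limits leave unreadable from compound 1 to compound 3, run between limits and give no readable size, so no direction can be drawn from them. The step is therefore expected as a step that the limit leaves unreadable from compound 1 to compound 4, a guess that compound 4 remains at the limit. Compound 4 is estimated at 15000 nM, with a range from 3000 nM to 60000 nM.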

Compound 4, half-maximal inhibitory concentration: > 10000 nM
Compound 4: no number, only a limit (the forecaster's own chance of this, stated with the estimate: 80%); the middle value does not contradict the limit.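

Compound 4 sits at a limit of the assay, as do compound 1, compound 2 and compound 3, so no step among them can be read: the limit of > 10000 nM in this assay, at which 4 of the 4 values shown sit.

The compounds shown leave open whether any group on the aromatic nitrogen gives a readable value in this assay.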